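The compounds below may be only part of what the source reports. "The series", "measured", "known", "first", "only" and "open" are said of these compounds alone.

Among the compounds with values here, in a functional assay on A549 cells (Homo sapiens) for antiproliferative activity, read by MTT assay, with a stated time of 48 h (a lower number here means a stronger inhibitor, a higher number a weaker inhibitor), compound 3 `O=C(/C=C\Nc1ccc(F)cc1)c1cn(-c2ccccc2)nc1-c1ccc(F)cc1` gives 5780 nM, which places it second highest of the three numbers known so far. Compound 1 `O=C(/C=C\Nc1ccc(F)cc1)c1cn(-c2ccccc2)nc1-c1ccccc1` gives 4670 nM, and the change from compound 1 to compound 3, fluoro in place of hydrogen on an aromatic carbon, amounts to a 1.2-fold higher number from compound 1 to compound 3 (0.09 log units; within the scatter). Compound 2 `O=C(/C=C\Nc1ccc(Cl)cc1)c1cn(-c2ccccc2)nc1-c1ccccc1` gives 14100 nM, and the step from compound 1 to compound 2 is a 3.0-fold higher number from compound 1 to compound 2 (0.48 log units; beyond the scatter). Compound 4 `O=C(/C=C\Nc1ccc(Cl)cc1)c1cn(-c2ccccc2)nc1-c1ccc(F)cc1` has not yet been measured. It differs from compound 3 in one place: chloro in place of fluoro on an aromatic carbon. Within the data shown here, the step from compound 1 to compound 2 is the same exchange carried out on the core of compound 1, so it is the one measured step that bears on this question; it was a modest move toward a higher number, beyond the scatter. On that basis a step of similar size and in the same direction is expected from compound 3 to compound 4, namely a 2.9-fold higher number from compound 3 to compound 4 (0.47 log units; beyond the scatter). Compound 4 is therefore estimated to give 17000 nM in this assay, with a likely range from 8000 nM to 40000 nM.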

Compound 4, half-maximal inhibitory concentration: 6700 nM
Beside the measured number, compound 4's estimate is 2.5-fold (0.40 log units) above it, and the stated range ends above it.
By their numbers in this assay, from the lowest: compounds 1, 3 and 4 (each within the scatter of the next); then compound 2.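

With chloro in place of fluoro at this place, this assay shows a 1.2-fold higher number from compound 3 to compound 4 (0.06 log units; within the scatter) and so the clear rise seen on the core of compound 1 does not appear on this second core, yet the two steps cannot be told apart: the same change on two cores in this assay, a 3.0-fold higher number (0.48 log units; beyond the scatter) from compound 1 to compound 2 and a 1.2-fold higher number (0.06 log units; within the scatter) from compound 3 to compound 4, 2.6-fold (0.42 log units) apart, within the scatter of two such steps.
The reverse reading is similar, for fluoro in place of hydrogen gives a 2.1-fold lower number from compound 2 to compound 4 (0.32 log units; beyond the scatter) and so has a measurable effect only when the 4-chlorophenyl group is present, but this contrast also stays inside the expected noise: the same change on two cores in this assay, a 1.2-fold higher number (0.09 log units; within the scatter) from compound 1 to compound 3 and a 2.1-fold lower number (0.32 log units; beyond the scatter) from compound 2 to compound 4, 2.6-fold (0.42 log units) apart, within the scatter of two such steps.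
So these four compounds show no firm dependence of either change on the other.

The compounds shown leave open how a bromo, methoxy or dimethylamino group would behave on this ring. They also leave open whether a larger set would separate the two steps.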